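Phenoxy for phenyl in a thioether enone series

A few compounds are considered here, and "the series" means these few. Any claim that something is new, unique, unknown or untested is made for them only; others in the source may bear on it.

The series comprises three measured compounds and one untested analogue. Compound 1 `Cc1ccc(S/C(=C/c2ccc(-c3ccccc3)cc2)C(=O)c2ccc(Cl)cc2)cc1` and compound 2 `Cc1ccc(S/C(=C/c2ccc(-c3ccccc3)cc2)C(=O)c2ccc(Br)cc2)cc1` share a core and differ only in the halogen; compound 3 `O=C(/C(=C\c1ccc(O)c([N+](=O)[O-])c1)SCc1ccc(Br)cc1)c1ccc(Br)cc1` carries a different substitution pattern altogether. In a functional assay on DU-145 cells (Homo sapiens) for inhibition, read by trypan blue exclusion, with a stated time of 96 h (a higher number here means a weaker inhibitor of growth, a lower number a stronger inhibitor of growth), compound 1 gives 50000 nM, compound 2 gives 50000 nM, and compound 3 gives 10000 nM. Among the measured compounds shown here, the single one-point step, no change at the digits printed from compound 1 to compound 2 (within the scatter), shows that bromo in place of chloro leaves the read-out unchanged. Compound 2 therefore stands level with compound 1, both at the highest value of the three, while compound 3 lies below them by a margin beyond the scatter.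

Compound 4 `Cc1ccc(S/C(=C/c2ccc(Oc3ccccc3)cc2)C(=O)c2ccc(Br)cc2)cc1` differs from compound 2 by phenoxy in place of phenyl on an aromatic carbon, the change sitting on an aromatic carbon para to a large group. For the measured compounds named here, no measured step speaks to this exchange; the only step available concerns the halogen and was flat. With nothing to point to a gain, the step of a 1.3-fold lower number from compound 2 to compound 4 (0.10 log units; within the scatter) is expected to stay within the scatter in this assay. Compound 4 is accordingly estimated at 40000 nM, with a range from 12000 nM to 60000 nM.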

Compound 4, concentration for 50% growth inhibition: 1000 nM
Compound 4: the middle estimate sits 40-fold (1.60 log units) above what was measured; the whole stated range lies above it.
By their numbers in this assay, from the lowest: compound 4; then compound 3; then compounds 1 and 2 (each within the scatter of the next).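

In this assay, phenoxy in place of phenyl on an aromatic carbon para to a large group gives a 50-fold lower number from compound 2 to compound 4 (1.70 log units; beyond the scatter), so the read-out responds strongly to the group at this place, whereas the halogen exchange gave no change at the digits printed from compound 1 to compound 2 (within the scatter). The group that enters keeps the six-membered aromatic ring of carbon only and adds 1 oxygen, so a change confined to this one group is enough to separate compound 4 from compound 2 by a margin well beyond the scatter. No measurement available here explains why this exchange has so large an effect.

The compounds shown leave open whether the oxygen itself matters or any linking atom would serve, as a methylene, a sulfur or an amine nitrogen in its place could show. They also leave open whether the phenoxy gain carries over to the chloro analogue of compound 1, and how a substituent such as methoxy or a carboxylic acid on the terminal ring of the phenoxy group would change the read-out.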